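The source may hold more compounds than are shown below. What is called first, only, known or untested is meant among the compounds shown, and "the series" means these compounds.

Working notes on the series. In a functional assay on HOP-62 cells (Homo sapiens) for inhibition, read by sulforhodamine B assay (a higher number here means a weaker inhibitor of growth, a lower number a stronger inhibitor of growth), compound 1 (`Fc1ccc(-c2ccc(-c3ccc(-c4nc5ccccc5[nH]4)cc3)cc2)cc1`) gives 39300 nM, compound 2 (`FC(F)(F)c1ccc(-c2ccc(-c3ccc(-c4nc5ccccc5[nH]4)cc3)cc2)cc1`) gives 100000 nM, and compound 3 (`Oc1cccc2[nH]c(-c3ccc(-c4ccc(-c5ccc(C(F)(F)F)cc5)cc4)cc3)nc12`) gives 3200 nM, the lowest number of the three. Still unmeasured is compound 4 (`CN(C)c1ccc(-c2ccc(-c3ccc(-c4nc5c(O)cccc5[nH]4)cc3)cc2)cc1`), in which dimethylamino takes the place of trifluoromethyl on an aromatic carbon, para to a large group: dimethylamino in place of trifluoromethyl on an aromatic carbon. Within the data shown here, only one measured step involves this place: a 2.5-fold higher number from compound 1 to compound 2 (0.41 log units; beyond the scatter), a modest change with trifluoromethyl in place of fluoro. The large step of a 31-fold lower number from compound 2 to compound 3 (1.49 log units; beyond the scatter) is hydroxy in place of hydrogen, and compound 4 keeps that hydroxy. Among the measured compounds shown here, no measured compound carries dimethylamino, so the direction rests on thin evidence. Losing trifluoromethyl is tentatively expected to lower the number a little, and a step larger than the modest one from fluoro to trifluoromethyl is not anticipated. The estimated step is a 1.6-fold lower number from compound 3 to compound 4 (0.20 log units; within the scatter). For compound 4 the expected value is 2000 nM, with an estimated range of 500 nM to 8000 nM.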

Compound 4, concentration for 50% growth inhibition: 8250 nM
Beside the measured number, compound 4's estimate is 4.1-fold (0.62 log units) below it; measured number above the stated range.
By their numbers in this assay, from the lowest: compound 3; then compound 4; then compound 1; then compound 2.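

In this assay, dimethylamino in place of trifluoromethyl, with the hydroxy kept, gives a 2.6-fold higher number from compound 3 to compound 4 (0.41 log units; beyond the scatter) and so moves the number up, the first measured sign that replacing trifluoromethyl at this position need not lower it. This step is modest beside a 31-fold lower number from compound 2 to compound 3 (1.49 log units; beyond the scatter) and matches the size of a 2.5-fold higher number from compound 1 to compound 2 (0.41 log units; beyond the scatter), so the two changes at this position read so far are both smaller than the hydroxy step, though they stand on different cores. Nothing shown gives a measured property that accounts for the rise at this position.

Still open, as far as these compounds go, is how fluoro, a carboxylic acid or a primary amine would read at this position with the hydroxy kept. Also open, from the compounds shown here alone, is whether the hydroxy step would be as large with dimethylamino in place.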